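This account rests on a few compounds, and the source may have more. Where it says the series, first, only, none or still open, it means among the compounds named here.

Two compounds share one core and differ only in the group that sits on an aromatic carbon of a six-membered aromatic ring of carbon only. Compound 1 `Cc1c(Cc2ccc(Cl)cc2)c(=O)oc2cc(OCC(O)CN3CCC(C(N)=O)CC3)ccc12` carries a chloro there, and in an ADME assay on A549 cells (Homo sapiens) for cytotoxicity, read by CellTiter-Glo (a higher number here means that more compound is tolerated, a lower number that less compound is tolerated), compound 1 gives 40000 nM. Among the measured compounds shown here, compound 2 `Cc1c(Cc2ccc(-c3ccc(F)cc3)cc2)c(=O)oc2cc(OCC(O)CN3CCC(C(N)=O)CC3)ccc12` carries a 4-fluorophenyl instead, and in this assay compound 2 gives 19300 nM, the lower of the two numbers measured so far; the only measured step, a 2.1-fold lower number from compound 1 to compound 2 (0.32 log units; beyond the scatter), separates them. Compound 3 `Cc1c(Cc2ccc(-c3ccc(C#N)c(F)c3)cc2)c(=O)oc2cc(OCC(O)CN3CCC(C(N)=O)CC3)ccc12` has not yet been measured. It differs from compound 2 in that (4-cyano-3-fluorophenyl in place of 4-fluorophenyl on an aromatic carbon). For the measured compounds named here, no measured step tests this kind of change: the one known step, a 2.1-fold lower number from compound 1 to compound 2 (0.32 log units; beyond the scatter), swaps chloro for 4-fluorophenyl, whereas the move to compound 3 keeps a phenyl ring in place and changes what it carries. Going by the values given here, with only that modest step as a guide, and none that bears directly, the change from compound 2 to compound 3 is expected to stay within or close to the usual scatter, with no clear direction. The expected step is a 1.2-fold lower number from compound 2 to compound 3 (0.08 log units; within the scatter). Compound 3 is therefore estimated at 16000 nM, with a range from 6000 nM to 45000 nM.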

Compound 3, half-maximal cytotoxic concentration: 29100 nM
Estimate against measurement, compound 3: 1.8-fold (0.26 log units) below; the range from low to high includes it.
By their numbers in this assay, from the lowest: compounds 2, 3 and 1 (each within the scatter of the next, the first and the last beyond it).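

In this assay the change to 4-cyano-3-fluorophenyl gives a 1.5-fold higher number from compound 2 to compound 3 (0.18 log units; within the scatter) and so shows that this position can take a larger group, with a nitrile and one hydrogen-bond acceptor more, without a change that stands clear of the scatter. Compound 3 also cannot be separated from the chloro compound, with a 1.4-fold lower number from compound 1 to compound 3 (0.14 log units; within the scatter) as its step, even though the earlier step of a 2.1-fold lower number from compound 1 to compound 2 (0.32 log units; beyond the scatter) lay beyond the scatter. Putting a substituted phenyl ring at this place in place of chloro therefore does not always give a clear drop in the number, and compound 3 is the compound that goes against that reading, while no measured property here accounts for the difference between the two phenyl groups.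

From the compounds shown here alone, it remains open whether a phenyl ring carrying an amine or a carboxylic acid would move the number beyond the scatter in either direction. The two groups that changed together on the ring of compound 3 also remain unseparated, so a 4-cyanophenyl group would be needed to show what the nitrile does without the fluorine in its new place.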